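From Dimethylamino to Amino on the Potent Core

The source may hold more compounds than are shown below. What is called first, only, known or untested is meant among the compounds shown, and "the series" means these compounds.

Going by the values given here, compound 2 `CN(C)C(=S)N/N=C/c1ccc2ccccc2n1` is the only compound here with a measured number: in a functional assay on HL-60 cells (Homo sapiens) for antiproliferative activity, read by sulforhodamine B assay, with a stated time of 72 h (a lower number here means a stronger inhibitor, a higher number a weaker inhibitor), compound 2 gives 50 nM. Compound 1 `CN(C)C(=S)N/N=C/c1cc2cccnc2s1` carries the same dimethylamino thiocarbonyl group on a different core. In this assay compound 1 reaches only a limit of the assay, > 100000 nM. Compound 3 `NC(=S)N/N=C/c1cc2cccnc2s1` keeps the core of compound 1 and has an amino group where compound 1 has dimethylamino. In this assay compound 3 also reaches only a limit, > 100000 nM. Among the compounds with values here, because both values sit at the limit of > 100000 nM in this assay, at which 2 of the 3 values shown sit, the one measured step with this change, a step that the two limits leave unreadable from compound 1 to compound 3, cannot be read for size or direction.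

Compound 4 `NC(=S)N/N=C/c1ccc2ccccc2n1` is compound 2 carrying exactly that change: amino in place of dimethylamino on a thiocarbonyl carbon. Within the data shown here, no measured step of readable size bears on it, so the expectation rests on compound 2 alone and must be wide. Compound 4 is expected to give 1500 nM in this assay, with a plausible range from 150 nM to 15000 nM. That estimate means an expected step of a 30-fold higher number from compound 2 to compound 4 (1.48 log units; beyond the scatter), a weakening that would lie beyond the usual scatter, though the width of the range allows for little change as well.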

Compound 4, half-maximal inhibitory concentration: > 100000 nM
Compound 4 was reported as a limit (the forecaster's own chance of this, stated with the estimate: 15%); middle value at least 66-fold (1.82 log units) from the limit.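

On the core of compound 2, the change to amino from dimethylamino on a thiocarbonyl carbon can now be read, and in this assay it gives an at least 2000-fold higher number from compound 2 to compound 4 (3.30 log units; beyond the scatter). The same change on the core of compound 1 could not be read, as both of its values are limits, so this pair gives the first sign that the dimethylamino group matters, and it does so on the one core where a measured number exists. That step is only a lower bound, and its full size stays unknown, as the value of compound 4 is a limit of the assay and not a number: the limit of > 100000 nM in this assay, at which 3 of the 4 values shown sit.

The dimethylamino group is clearly not enough by itself, as compound 1 carries it and still sits at a limit, so its importance is shown here for the core of compound 2 alone. The compounds shown leave open whether a group between the two, such as methylamino, would keep part of the activity on this core, and whether a larger one, such as diethylamino, would hold it or improve on it.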